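Hydroxyphenyl placement in an enone series for alpha glucosidase

The compounds below may be only part of what the source reports. "The series", "measured", "known", "first", "only" and "open" are said of these compounds alone.

compound 1 `O=C(C1=C(O)/C(=C/c2ccc(O)c(O)c2)CCC1)c1ccccc1` — 55.9%
compound 2 `O=C1/C(=C/c2ccccc2)CCC/C1=C\c1ccc(Br)cc1` — 29.1%
compound 3 `O=C(C1=C(O)/C(=C/c2ccc(O)cc2)CCC1)c1ccccc1` — 34.9%

All three were measured in an assay on isolated protein for inhibition of Alpha glucosidase (Homo sapiens), with stated times of 5 min and 15 min, tested at 50 uM; a lower number here means less inhibition, a higher number more inhibition at the concentration tested (going by the name of the read-out). Going by the values given here, compound 3 stands second highest of the three numbers: compound 2 lies within the scatter of it, while compound 1 is separated from it beyond the scatter, and a number 21 percentage points lower from compound 1 to compound 3 (beyond the scatter) is the only single-change step measured so far. Compound 4 `O=C(C1=C(O)/C(=C/c2cccc(O)c2)CCC1)c1ccccc1` differs from compound 3 by 3-hydroxyphenyl in place of 4-hydroxyphenyl on a double-bonded chain carbon bound to a double-bonded ring carbon. Among the compounds with values here, no measured step bears directly on this change; the one step known removes a hydroxy rather than relocating it, so it gives little guidance. The expectation for this assay is a step of no size beyond the scatter, a number 0.1 percentage points higher from compound 3 to compound 4 (within the scatter). Compound 4 is accordingly estimated at 35%, within a range from 15% to 55%.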

Compound 4, a percentage reported as inhibition, at one concentration (the size of the read-out at that concentration, not a potency): 43.2%
Beside the measured number, compound 4's estimate is 8.2 percentage points below it, and the stated range covers the measured number.
By their numbers in this assay, from the lowest: compounds 2, 3 and 4 (each within the scatter of the next, the first and the last beyond it); then compound 1.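

Placing the hydroxy as 3-hydroxyphenyl rather than 4-hydroxyphenyl gives a number 8.3 percentage points higher from compound 3 to compound 4 (within the scatter) and so does not separate the two placements at this position. With a number 12.7 percentage points lower from compound 1 to compound 4 (beyond the scatter) standing alongside a number 21 percentage points lower from compound 1 to compound 3 (beyond the scatter) in the same direction, the loss of either hydroxy from compound 1 gives a step beyond the scatter. Nothing available explains these numbers.

Still open, on these data alone, is whether a methoxy or an amine in place of the hydroxy on the 3-hydroxyphenyl group would keep the number of compound 4. As far as these compounds go, a 2-hydroxyphenyl group at this position also remains open.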